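From 4-Methylphenyl to (Diallylamino)methyl on the Carbonyl

The source may report more compounds than this note shows. Statements on the series, on what has been measured and on what is new or still open speak of the compounds shown alone.

In a functional assay on HepG2 cells (Homo sapiens) for cytotoxicity, read by MTT assay, with a stated time of 48 h (on this read-out higher numbers stand for weaker inhibition and lower numbers for stronger inhibition), compound 1 `CC1=NN(C(=O)c2ccc(C)cc2)C(c2cc(Br)ccc2O)C1` gives 23200 nM. Among the compounds with values here, this is the only number available so far, so compound 1 cannot yet be ranked against another measured value. In this assay, compound 2 `CC1=NN(C(=O)c2ccc(C)cc2)C(c2cc(Br)cc(Br)c2O)C1` is recorded as "not active" (no number reported), with no number attached.

Compound 3 `C=CCN(CC=C)CC(=O)N1N=C(C)CC1c1cc(Br)ccc1O` has not been measured. It keeps the core of compound 1 and alters one group: (diallylamino)methyl in place of 4-methylphenyl on a carbonyl carbon. Here (diallylamino)methyl stands in place of 4-methylphenyl on a carbonyl carbon. Within the data shown here, no measured pair shows what such a swap does, so any forecast is uncertain and the range must stay wide. The estimated change, a 1.2-fold lower number from compound 1 to compound 3 (0.06 log units; within the scatter), is expected to stay within the usual scatter, with no clear direction. For compound 3 the expected value is 20000 nM, with an estimated range from 6000 nM to 70000 nM.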

Compound 3, half-maximal inhibitory concentration: 7870 nM
The estimate for compound 3 lay 2.5-fold (0.41 log units) above the measured number, within the range that was stated.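

In this assay, putting (diallylamino)methyl in place of 4-methylphenyl on a carbonyl carbon gives a 2.9-fold lower number from compound 1 to compound 3 (0.47 log units; beyond the scatter), a modest step but one beyond the scatter, towards stronger inhibition. Within the data shown here, this is the first measured step at this position, and it shows that the six-membered aromatic ring of compound 1 is not required there for activity in this cell assay: a group with no ring and with a nitrogen is tolerated and does somewhat better. No measurement shown here explains why the number falls.

This single step cannot separate the loss of the ring from the gain of the nitrogen or of the double bonds. On these data alone, a (dimethylamino)methyl group on the same carbonyl carbon would be a direct test of whether the allyl chains matter, and whether a simple amine is enough remains open.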